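The source may hold more compounds than are shown below. What is called first, only, known or untested is meant among the compounds shown, and "the series" means these compounds.

Notes on the series. The shared core is shown by compound 1 `O=C(/C=C/c1ccc2c(c1)B(O)OC2)c1cccs1`. For the measured compounds named here, in a functional assay on HCT-116 cells (Homo sapiens) for cytotoxicity, read by MTT assay, with a stated time of 48 h (a higher number here means a weaker inhibitor, a lower number a stronger inhibitor), compound 1 gives 14200 nM, the highest of the three numbers measured so far. Compound 2 `O=C(/C=C/c1ccc2c(c1)B(O)OC2)c1ccccc1F` gives 4200 nM and compound 3 `Cc1ccc(C(=O)/C=C/c2ccc3c(c2)B(O)OC3)cc1C` gives 6100 nM; both numbers lie below that of compound 1, and the gap to each of them is beyond the scatter.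

Going by the values given here, the only step measured in one place from compound 1 is the exchange on the carbonyl carbon: a 3.4-fold lower number from compound 1 to compound 2 (0.53 log units; beyond the scatter), a modest change in which a six-membered aromatic ring of carbon only takes the place of the thiophen-2-yl.

Compound 4 `Nc1cccc(C(=O)/C=C/c2ccc3c(c2)B(O)OC3)c1` is not yet measured. It differs from compound 1 in the same place: 3-aminophenyl in place of thiophen-2-yl on a carbonyl carbon. The step from compound 1 to compound 2 is the one that bears on it; compound 3 also carries a six-membered aromatic ring of carbon only on the carbonyl carbon and also shows a lower number than compound 1. Both cases point to a lower number for compound 4 in this assay, of modest size, although the entering 3-aminophenyl brings one hydrogen-bond donor that neither compound 2 nor compound 3 carries, so the expected step is taken as somewhat smaller than that to compound 2. The expected step is a 2.4-fold lower number from compound 1 to compound 4 (0.37 log units; beyond the scatter). Compound 4 is expected to give 6000 nM, within a range of 2500 nM to 14000 nM.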

Compound 4, half-maximal inhibitory concentration: 4500 nM
For compound 4 the middle estimate is 1.3-fold (0.12 log units) above the measured one, within the range that was stated.
By their numbers in this assay, from the lowest: compounds 2, 4 and 3 (each within the scatter of the next); then compound 1.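

In this assay the exchange on the carbonyl carbon now has a second one-place step, a 3.2-fold lower number from compound 1 to compound 4 (0.50 log units; beyond the scatter), again modest, and it comes with a different group on the six-membered aromatic ring of carbon only, so the lower number is no longer tied to 2-fluorophenyl alone. The step of a 1.1-fold higher number from compound 2 to compound 4 (0.03 log units; within the scatter) does not separate 3-aminophenyl from 2-fluorophenyl at this place, and the hydrogen-bond donor that enters with 3-aminophenyl therefore goes with no difference beyond the scatter in this comparison. Nothing at hand bears on why the number falls when either group takes the place of thiophen-2-yl.

The compounds shown leave open how much of the step belongs to the six-membered ring itself and how much to what it carries: a plain phenyl would set the reference, and a carboxylic acid or a methoxy group on the ring would test whether the tolerance seen here extends beyond fluorine and an amine. They also leave open whether the high number of compound 1 belongs to thiophen-2-yl in particular or to five-membered aromatic rings more widely, a question that furan-2-yl or thiazol-2-yl at the same carbonyl carbon would address.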